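This account rests on a few compounds, and the source may have more. Where it says the series, first, only, none or still open, it means among the compounds named here.

In an ADME assay on Vero cells (Chlorocebus sabaeus) for cytotoxicity, read by resazurin assay, with a stated time of 72 h (a higher number here means a weaker inhibitor, a lower number a stronger inhibitor), compound 1 `Cc1ccc(C(=O)CCN2CCN(c3ccc(Cl)cc3)CC2)cc1` gives 184000 nM. Compound 2 `Cc1ccc(C(=O)CCN2CCN(c3ccc([N+](=O)[O-])cc3)CC2)cc1` carries nitro in place of chloro on an aromatic carbon and gives 235000 nM, a change of a 1.3-fold higher number from compound 1 to compound 2 (0.11 log units; within the scatter). Compound 3 `O=C(CCN1CCN(c2ccc(Cl)cc2)CC1)c1ccc(F)c(F)c1` differs from compound 1 by 3,4-difluorophenyl in place of 4-methylphenyl on a carbonyl carbon. In this assay compound 3 gives 86200 nM, the lowest of the three numbers, with a 2.1-fold lower number from compound 1 to compound 3 (0.33 log units; beyond the scatter). Compound 4 `O=C(CCN1CCN(c2ccc([N+](=O)[O-])cc2)CC1)c1ccc(F)c(F)c1` has not yet been measured in this assay; it differs from compound 3 by nitro in place of chloro on an aromatic carbon, the same change that was made from compound 1 to compound 2, at the same place on the ring. Because that earlier change gave a 1.3-fold higher number from compound 1 to compound 2 (0.11 log units; within the scatter), the step for compound 4 is expected to be of similar size, namely a 1.3-fold higher number from compound 3 to compound 4 (0.11 log units; within the scatter). Compound 4 is therefore estimated at 110000 nM, with a likely range from 55000 nM to 220000 nM.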

Compound 4, half-maximal inhibitory concentration: 122000 nM
Beside the measured number, compound 4's estimate is 1.1-fold (0.04 log units) below it; the range from low to high includes it.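

Nitro in place of chloro gives a 1.4-fold higher number from compound 3 to compound 4 (0.15 log units; within the scatter) in this assay, and this agrees with the same change made earlier: the same change on two cores in this assay, a 1.3-fold higher number (0.11 log units; within the scatter) from compound 1 to compound 2 and a 1.4-fold higher number (0.15 log units; within the scatter) from compound 3 to compound 4, 1.1-fold (0.04 log units) apart, within the scatter of two such steps. 3,4-Difluorophenyl in place of 4-methylphenyl gives a 1.9-fold lower number from compound 2 to compound 4 (0.28 log units; within the scatter), and this too agrees with its earlier step: the same change on two cores in this assay, a 2.1-fold lower number (0.33 log units; beyond the scatter) from compound 1 to compound 3 and a 1.9-fold lower number (0.28 log units; within the scatter) from compound 2 to compound 4, 1.1-fold (0.04 log units) apart, within the scatter of two such steps. Across these four compounds each change therefore carries from one core to the other at much the same size, but this does not show that it would hold on any further core, and the nitro step stays within the scatter on both cores, so no real effect of that change is shown.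

The compounds shown leave open whether a nitrile, an amine or a carboxylic acid in place of chloro would carry over in the same way. They also leave open what a longer chain to the carbonyl would do.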